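Swapping the ring nitrogen substituent of a peptide-linked thiazolidinedione

This account rests on a few compounds, and the source may have more. Where it says the series, first, only, none or still open, it means among the compounds named here.

Measured compounds:
- compound 1, `CCCC[C@H](NC(=O)[C@H](CCCCN)NC(=O)[C@H](CCCNC(=N)N)NC(=O)c1ccc(/C=C2\SC(=O)N(c3ccc(C)cc3)C2=O)cc1)C(N)=O`: 0.66 10^-6 cm/s
- compound 2, `CCCC[C@H](NC(=O)[C@H](CCCCN)NC(=O)[C@H](CCCNC(=N)N)NC(=O)c1ccc(/C=C2\NC(=S)N(c3ccccc3)C2=O)cc1)C(N)=O`: "impermeable" (no number reported)

Among the compounds with values here, compound 1 is the only compound of the pair to give a number in an ADME assay for permeability, using PAMPA; on this read-out higher numbers stand for higher permeability and lower numbers for lower permeability; compound 2, which differs from it in the core ring, is simply reported as "impermeable" (no number reported) with no value attached. Compound 1 therefore stands alone as the reference point for what a measurable result looks like in this series, and its number is low.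

Compound 3, `CCCC[C@H](NC(=O)[C@H](CCCCN)NC(=O)[C@H](CCCNC(=N)N)NC(=O)c1ccc(/C=C2\SC(=O)N(Cc3ccc(Cl)cc3)C2=O)cc1)C(N)=O`, is the next compound to be tested. Its change from compound 1 is 4-chlorobenzyl in place of 4-methylphenyl on an amide-type nitrogen in a ring. Both groups leaving and entering carry no hydrogen-bond donors or acceptors and no charge, and the rest of the molecule, including the long peptide tail, is unchanged. Within the data shown here, with no measured step of this kind to lean on, the expectation is a step from compound 1 to compound 3 that stays within the scatter of repeated measurements, in no particular direction.

Compound 3 is therefore expected to give 0.7 10^-6 cm/s in this assay, within a range of 0.3 10^-6 cm/s to 1.6 10^-6 cm/s, an expected step of a 1.1-fold higher number from compound 1 to compound 3 (0.03 log units; within the scatter).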

Compound 3, apparent permeability: 1.11 10^-6 cm/s
For compound 3 the middle estimate is 1.6-fold (0.20 log units) below the measured one; the measured number falls inside the stated range.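

Within the data shown here, compound 3 gives the series a second number in this assay and so provides the first measured step at the amide-type nitrogen in the ring: 4-chlorobenzyl in place of 4-methylphenyl gives a 1.7-fold higher number from compound 1 to compound 3 (0.23 log units; within the scatter) and leaves the two compounds indistinguishable on this read-out. The entering group has one more heavy atom than the group it replaces, and it brings a chlorine atom, yet compound 1 and compound 3 both give a number and the exchange of one uncharged group for another produces no step beyond the scatter. No measurement is available that could explain the result for this pair.

This single exchange alters both the link to the aromatic ring and the group carried on that ring, so a plain benzyl or a 4-chlorophenyl group would be needed to take those two changes apart. On these data alone, it also remains open how this read-out responds when the same nitrogen carries something of a different kind, such as an amine, a carboxylic acid or a longer chain.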